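Alpha-branched aryloxy acids on the shared core

The source may report more compounds than this note shows. Statements on the series, on what has been measured and on what is new or still open speak of the compounds shown alone.

Measured compounds:
compound 1 `O=C(O)COc1cccc(CCCn2cc(C(c3ccccc3)c3ccccc3)ccc2=O)c1`, 256 nM
compound 2 `COc1ccc(C(=O)N(CCCc2cccc(OCC(=O)O)c2)CCC(c2ccccc2)c2ccccc2)cc1`, 17 nM
compound 3 `CCC(Oc1cccc(CCCn2cc(C(c3ccccc3)c3ccccc3)ccc2=O)c1)C(=O)O`, 990 nM

All three were run in an assay on HEK293 cells for displacement of a labelled ligand from chemoattractant receptor-homologous molecule expressed on Th2 cells (Cavia porcellus), read by scintillation counting, with a stated time of 2 h; a higher number here means a weaker inhibitor, a lower number a stronger inhibitor. Compound 3 stands at the highest number of the three: compound 1 is the nearest, with a step of a 3.9-fold higher number from compound 1 to compound 3 (0.59 log units; beyond the scatter), and compound 2 is the furthest, its value lying well below that of compound 3.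

The next compound, compound 4 `CC(C)(Oc1cccc(CCCn2cc(C(c3ccccc3)c3ccccc3)ccc2=O)c1)C(=O)O`, differs from compound 3 in one place: 1-carboxy-1-methylethyl in place of 1-carboxypropyl on an oxygen on an aromatic ring. For the measured compounds named here, no measured pair shows exactly this exchange. Going by the values given here, the one measured step that touches this position is the move from compound 1 to compound 3, a 3.9-fold higher number from compound 1 to compound 3 (0.59 log units; beyond the scatter), which shows that branching on the carbon bound to the carbonyl and the aryl oxygen can shift the number by a modest amount. Compound 4 keeps a branch of the same size there, rearranged as two methyls instead of one ethyl, so the expectation is a step of small size, probably not beyond the scatter, with a slight lean back toward the number of compound 1.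

For compound 4 in this assay the estimate is 650 nM, with a range of 220 nM to 2000 nM, which means an expected step of a 1.5-fold lower number from compound 3 to compound 4 (0.18 log units; within the scatter).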

Compound 4, half-maximal inhibitory concentration: > 1000 nM
Compound 4: no number, only a limit; the forecaster's own chance of this, stated with the estimate: 2%; middle value at least 1.5-fold (0.18 log units) from the limit.
By their numbers in this assay, from the lowest: compound 2; then compound 1; then compound 3. At a limit, above all of these: compound 4.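

Compound 4 is held in this assay only as a limit: the limit of > 1000 nM in this assay, at which 1 of the 4 values shown sits.

Putting 1-carboxy-1-methylethyl in place of carboxymethyl on the oxygen on the aromatic ring gives an at least 3.9-fold higher number from compound 1 to compound 4 (0.59 log units; beyond the scatter). The higher number is therefore not confined to 1-carboxypropyl, as a 3.9-fold higher number from compound 1 to compound 3 (0.59 log units; beyond the scatter) alone might have allowed: both branched groups shown at this position go the same way from carboxymethyl, and no compound shown here goes against this. Between the two branched groups the data give only a number no lower from compound 3 to compound 4 (the limit leaves the size open), a step that cannot be read, and so 1-carboxypropyl and 1-carboxy-1-methylethyl stay unranked.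

On these data alone, it remains open whether 1-carboxyethyl, with a single methyl on that carbon, would stay near compound 1 at 256 nM or move as far as compound 3 at 990 nM. Also open, as far as these compounds go, is whether a longer chain between the oxygen on the aromatic ring and the carboxylic acid would carry a branch at a smaller cost than these groups do on the shared core.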